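Nitro to fluoro repeated on the second linker series

The source may hold more compounds than are shown below. What is called first, only, known or untested is meant among the compounds shown, and "the series" means these compounds.

Measured compounds:
Compound 1, `COc1cc(/C=C/c2ccc(NC(=O)/C=C/c3ccc([N+](=O)[O-])cc3)cc2)cc(OC)c1`, in a functional assay on MDA-MB-231 cells (Homo sapiens) for inhibition, read by MTT assay, with a stated time of 48 h (a lower number here means a stronger inhibitor, a higher number a weaker inhibitor), gives 11700 nM.
Compound 2, `COc1cc(/C=C/c2ccc(NC(=O)/C=C/c3ccc(F)cc3)cc2)cc(OC)c1`, in this assay gives 9390 nM.
Compound 3, `COc1cc(/C=C/c2ccc(OC(=O)/C=C/c3ccc([N+](=O)[O-])cc3)cc2)cc(OC)c1`, in this assay gives 18000 nM.

Compound 2 differs from compound 1 by fluoro in place of nitro on an aromatic carbon. The step was a 1.2-fold lower number from compound 1 to compound 2 (0.10 log units; within the scatter). The difference between the core of compound 1 and the core of compound 3 is not broken down here; the two values of compound 3 and compound 1 lie within the scatter of each other, as do those of compound 3 and compound 2, so no order among the three is read.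

Compound 4, `COc1cc(/C=C/c2ccc(OC(=O)/C=C/c3ccc(F)cc3)cc2)cc(OC)c1`, is not yet measured in this assay. It differs from compound 3 by fluoro in place of nitro on an aromatic carbon. The place is described in the same words as for the earlier pair, so this is the same change made on the core of compound 3.

The step from compound 3 to compound 4 is expected to be a 1.2-fold lower number from compound 3 to compound 4 (0.08 log units; within the scatter), which rests on the step of a 1.2-fold lower number from compound 1 to compound 2 (0.10 log units; within the scatter) seen on the other core. Compound 4 is therefore estimated at 15000 nM in this assay, with 7000 nM to 35000 nM as the likely range.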

Compound 4, half-maximal inhibitory concentration: 6210 nM
Estimate against measurement, compound 4: 2.4-fold (0.38 log units) above; measured number outside the range, below it.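

In this assay, fluoro in place of nitro on the core of compound 3 gives a 2.9-fold lower number from compound 3 to compound 4 (0.46 log units; beyond the scatter), a modest step beyond the scatter. Set beside the same change on the core of compound 1, the new step cannot be told apart from the earlier one: the same change on two cores in this assay, a 1.2-fold lower number (0.10 log units; within the scatter) from compound 1 to compound 2 and a 2.9-fold lower number (0.46 log units; beyond the scatter) from compound 3 to compound 4, 2.3-fold (0.37 log units) apart, within the scatter of two such steps. For the compounds shown here, the two pairs therefore fit a single shared effect of this change, and they show no dependence on the core, yet only the step on the core of compound 3 is beyond the scatter, so two pairs neither establish that the step has one fixed size nor exclude a modest core effect.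

From the compounds shown here alone, whether an amine, a carboxylic acid or a chloro group at the same place on the aromatic ring would read as nitro or as fluoro does stays open. Also open, going by these compounds, is whether the step would hold on a further core, such as one with a longer chain in the linker.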